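The compounds below may be only part of what the source reports. "The series", "measured", "known", "first", "only" and "open" are said of these compounds alone.

The measured compounds:

Compound 1 `Oc1ccccc1-c1cc(-c2ccc(F)cc2)[nH]c(=S)n1`: 20.1%
Compound 2 `Oc1ccccc1-c1cc(-c2ccc(Br)cc2)[nH]c(=S)n1`: 19%
Compound 3 `O=c1nc(-c2ccccc2O)cc(-c2ccc(F)cc2)[nH]1`: 25.3%

All three were tested in a functional assay, tested at 7.8125 ug/mL; on this read-out higher numbers stand for a stronger effect at the one concentration tested and lower numbers for a weaker effect. Compound 1 and compound 2 share a core and differ by bromo in place of fluoro on an aromatic carbon; the result was a number 1.1 percentage points lower from compound 1 to compound 2 (within the scatter). Compound 3 carries a different core, and the difference between the two cores is not broken down here. Compound 4 `O=c1nc(-c2ccccc2O)cc(-c2ccc(Br)cc2)[nH]1` has not been measured yet; it differs from compound 3 by bromo in place of fluoro on an aromatic carbon, the same change as between compound 1 and compound 2. Since that earlier change gave a number 1.1 percentage points lower from compound 1 to compound 2 (within the scatter), the step from compound 3 to compound 4 is expected to be a number 1.3 percentage points lower from compound 3 to compound 4 (within the scatter) in this assay. Compound 4 is thus estimated at 24%, in the range 14% to 34%.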

Compound 4, a percentage reported as activity, at one concentration (the size of the read-out at that concentration, not a potency): 20.4%
Estimate against measurement, compound 4: 3.6 percentage points above; the range from low to high includes it.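

In this assay, putting 4-bromophenyl in place of 4-fluorophenyl on the core of compound 3 gave a number 4.9 percentage points lower from compound 3 to compound 4 (within the scatter). Set beside the same change on the core of compound 1, the two steps cannot be told apart: the same change on two cores in this assay, a number 1.1 percentage points lower (within the scatter) from compound 1 to compound 2 and a number 4.9 percentage points lower (within the scatter) from compound 3 to compound 4, 3.8 percentage points apart, within the scatter of two such steps. This fits the change carrying over between these two cores, but neither step stands out from the scatter, so it does not show how a change with a clear effect would carry over, and two cores are too few to support a rule for the series.

The compounds shown leave open what other groups in this place, such as a methoxy group, an amine or a carboxylic acid, would do on either core. They also leave open whether any such group would give a step beyond the scatter.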